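This account rests on a few compounds, and the source may have more. Where it says the series, first, only, none or still open, it means among the compounds named here.

Compound 1, `CCCc1cccc(C[C@H](O)/C=C/[C@H]2CSC(=O)N2CCSCCCC(=O)O)c1`: 1200 nM
Compound 2, `CCc1cccc(C[C@H](O)/C=C/[C@H]2COC(=O)N2CCSCCCC(=O)O)c1`: 2700 nM

Both compounds were tested in an assay on CHO cells for displacement of a labelled ligand from prostaglandin E2 receptor EP3 subtype (Mus musculus), read by scintillation counting, with a stated time of 60 min; on this read-out higher numbers stand for weaker inhibition and lower numbers for stronger inhibition. Among the compounds with values here, compound 1 gives the lower of the two numbers, so it is the stronger inhibitor here; compound 2 differs from it in more than one place, and the gap between their values lies beyond the usual scatter, but no single step connects them.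

Compound 3, `COCc1cccc(C[C@H](O)/C=C/[C@H]2CSC(=O)N2CCSCCCC(=O)O)c1`, has not yet been measured. It differs from compound 1 in one place: methoxy in place of ethyl on a saturated chain carbon bound to an aromatic carbon. Within the data shown here, no measured pair shows this change on its own, so its effect cannot be read from the data. Replacing ethyl with methoxy at the same place is a modest change, and a small weakening, or no shift beyond the scatter, is expected in this assay. The expected step is a 1.7-fold higher number from compound 1 to compound 3 (0.22 log units; within the scatter). The estimate for compound 3 is 2000 nM, with a likely range from 600 nM to 6000 nM.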

Compound 3, inhibition constant: > 10000 nM
Compound 3: only a limit was reported (the forecaster's own chance of this, stated with the estimate: 5%); middle value at least 5.0-fold (0.69 log units) away from the limit.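

In this assay, methoxy in place of ethyl on a saturated chain carbon bound to an aromatic carbon gives an at least 8.3-fold higher number from compound 1 to compound 3 (0.92 log units; beyond the scatter), a loss far larger than expected for a change that exchanges one carbon for one oxygen and keeps the count of heavy atoms, so this place on the chain is sensitive to that exchange. Compound 3 is reported only as a limit, > 10000 nM. The step is therefore a minimum, and its full size stays unknown: the limit of > 10000 nM in this assay, at which 1 of the 3 values shown sits.

Going by these compounds, what remains open is whether the loss belongs to the oxygen alone or to any atom other than carbon at this place, which an amine there could help to separate. On these data alone, it is also open how a longer chain, such as butyl in place of the propyl of compound 1, would fare.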